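This account rests on a few compounds, and the source may have more. Where it says the series, first, only, none or still open, it means among the compounds named here.

Measured so far:
compound 1 `COc1cc(OC)c(OC)cc1/C=C/COC(=O)/C=C/c1ccc(OC)c(OC)c1` — 75%
compound 2 `COc1cc(OC)c(OC)cc1/C=C/COC(=O)/C=C/c1c(OC)ccc(OC)c1OC` — 75%
compound 3 `COc1cc(OC)c(OC)cc1/C=C/COC(=O)/C=C/c1cc(OC)c(OC)c(OC)c1OC` — 50%

All three were tested in a functional assay on the whole organism (strain Kunming) with Mus musculus as the target, with a stated time of 0.5 h, at a dose of 300 mg/kg by the intraperitoneal route; a higher number here means a weaker effect of the compound at the dose given, a lower number a stronger effect. Compound 1 gives 75% and compound 2 gives 75%; these two values lie within the scatter of each other. Compound 3 gives 50%, the lowest of the three numbers, and its distance to compound 1 as well as to compound 2 is beyond the scatter, so compound 3 shows the strongest effect among the measured compounds.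

Compound 4 `COc1cc(OC)c(OC)cc1/C=C/COC(=O)/C=C/c1cc(OC)c(OC)c(OC)c1` has not been measured. It differs from compound 3 in one place: hydrogen in place of methoxy on an aromatic carbon. Within the data shown here, no step between measured compounds matches this change, so the expectation rests on the spread seen so far. Because compound 1 gives 75% and compound 2 gives 75%, and only compound 3 sits lower, the expected step of a number 15 percentage points higher from compound 3 to compound 4 (beyond the scatter) is upward, toward a weaker effect, beyond the scatter. Compound 4 is expected to give about 65%, estimated between 50% and 80%.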

Compound 4, a percentage reported as activity, at one dose (the size of the read-out at that dose, not a potency): 75%
The estimate for compound 4 lay 10 percentage points below the measured number, within the range that was stated.
By their numbers in this assay, from the lowest: compound 3; then compounds 1, 2 and 4 (each within the scatter of the next).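

Within this assay the loss of this one methoxy, on the aromatic carbon ortho to a large group, gives a number 25 percentage points higher from compound 3 to compound 4 (beyond the scatter) and so a weaker effect at the dose given. Among these compounds, this is the first direct sign that the stronger effect of compound 3 goes with a methoxy at this position. A methoxy in place of hydrogen on an aromatic carbon of compound 1, by contrast, gives no change at the digits printed from compound 1 to compound 4 (within the scatter) and so leaves the read-out unchanged, which shows that adding a methoxy does not strengthen the effect wherever it is placed.

Nothing available here explains why this position matters. Going by these compounds, whether a hydroxyl, an amine or a longer chain such as ethoxy at this position would keep the stronger effect remains open.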